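The compounds below may be only part of what the source reports. "The series", "measured", "known", "first", "only" and "open" are said of these compounds alone.

Measured in a functional assay on DLD-1 cells (Homo sapiens) for cytotoxicity, with a stated time of 48 h; a higher number here means a weaker inhibitor, a lower number a stronger inhibitor:
- Compound 1 `CCOc1ccc2oc(/C=C/[S+](C)[O-])cc(=O)c2c1`: 4900 nM
- Compound 2 `CC(=O)Oc1ccc2oc(/C=C/[S+](C)[O-])cc(=O)c2c1`: > 10000 nM (a limit, not a number)

Compound 2 stands at the limit of > 10000 nM in this assay, at which 1 of the 2 values shown sits. Its position is therefore known only as a limit.

Compound 3 `CCCC(=O)Oc1ccc2oc(/C=C/[S+](C)[O-])cc(=O)c2c1` has not yet been measured. Its difference from compound 2 is ethyl in place of hydrogen on a saturated chain carbon bound to a carbonyl carbon. Put another way, acetoxy becomes (propylcarbonyl)oxy.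

Among the measured compounds shown here, the only measured step is an at least 2.0-fold higher number from compound 1 to compound 2 (0.30 log units; that floor lies within the scatter). That step places acetyl where ethyl stood on an oxygen on an aromatic ring, so it is a different change and gives no size for the present one. On that basis, no step beyond the scatter is expected in this assay, and no direction can be assigned. The expected step is a number no higher from compound 2 to compound 3 (the limit leaves the size open).

For compound 3 the estimated value is 10000 nM, with an expected range of 4000 nM to 25000 nM.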

Compound 3, half-maximal inhibitory concentration: 8700 nM
Compound 3: the middle estimate sits 1.1-fold (0.06 log units) above what was measured, within the range that was stated.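

On the oxygen on the aromatic ring, compound 3 with its (propylcarbonyl)oxy group gives a numeric value in this assay, 8700 nM, so a carbonyl-linked group at this oxygen does not by itself rule out a numeric value. Compound 2 still has a limit, not a number: the limit of > 10000 nM in this assay, at which 1 of the 3 values shown sits.

Read against the two neighbours, acetyl to propylcarbonyl gives an at least 1.1-fold lower number from compound 2 to compound 3 (0.06 log units; that floor lies within the scatter), and propylcarbonyl in place of ethyl gives a 1.8-fold higher number from compound 1 to compound 3 (0.25 log units; within the scatter), so neither printed step shows a change beyond the scatter.

On these data alone, the true size of the step from acetyl to propylcarbonyl stays open, with only a floor available. Also open, as far as these compounds go, is whether a longer chain on this carbonyl, or an amine at the end of the chain, would move the value beyond the scatter in this assay.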